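Dinitrophenyl ester at the oxime oxygen of compound 3

The source may hold more compounds than are shown below. What is called first, only, known or untested is meant among the compounds shown, and "the series" means these compounds.

Measured in a functional assay, with a stated time of 30 min; a lower number here means a stronger inhibitor, a higher number a weaker inhibitor:
compound 1 `COc1ccc(C2CC(=NO)CC(c3ccc(OC)cc3)N2C)cc1` gives 380000 nM
compound 2 `COc1ccc(C2CC(=NOC(=O)c3ccccc3)CC(c3ccc(OC)cc3)N2C)cc1` gives 375000 nM
compound 3 `COc1ccc(C2CC(=NOC(=O)c3ccc(Cl)cc3)CC(c3ccc(OC)cc3)N2C)cc1` gives 135000 nM

Compound 3 has the lowest number of the three, beyond the scatter from both compound 2 and compound 1. Compound 4 `COc1ccc(C2CC(=NOC(=O)c3cc([N+](=O)[O-])cc([N+](=O)[O-])c3)CC(c3ccc(OC)cc3)N2C)cc1` differs from it by 3,5-dinitrophenyl in place of 4-chlorophenyl on a carbonyl carbon. Among the measured compounds shown here, two steps bear on this: a 1.0-fold lower number from compound 1 to compound 2 (0.01 log units; within the scatter), and a 2.8-fold lower number from compound 2 to compound 3 (0.44 log units; beyond the scatter). The ester alone changed nothing, while a substituent on that ring gave a modest step, so a modest step in this assay is plausible, its direction uncertain. Compound 4 is therefore expected to give about 110000 nM, within 30000 nM to 400000 nM, which is an expected 1.2-fold lower number from compound 3 to compound 4 (0.09 log units; within the scatter).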

Compound 4, half-maximal inhibitory concentration: 312000 nM
Compound 4: middle estimate off by 2.8-fold (0.45 log units), on the low side; the range from low to high includes it.
By their numbers in this assay, from the lowest: compound 3; then compounds 4, 2 and 1 (each within the scatter of the next).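

In this assay the step of a 2.3-fold higher number from compound 3 to compound 4 (0.36 log units; beyond the scatter) shows that the lower number of the chlorinated ester does not extend to every substituted aryl group on this carbonyl carbon. The step of a 1.2-fold lower number from compound 2 to compound 4 (0.08 log units; within the scatter) leaves these two esters indistinguishable, so 3,5-dinitrophenyl performs no differently here from plain phenyl. No evidence is available to account for this result. Still open, as far as these compounds go, is whether a phenyl ring bearing one nitro group or an amine would behave like 4-chlorophenyl or like 3,5-dinitrophenyl. Also open, from the compounds shown here alone, is how an acetyl group, without any aromatic ring, would fare on the oxime oxygen.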